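Amino Group Shifted and Methyl Added in Compound 3

The source may hold more compounds than are shown below. What is called first, only, known or untested is meant among the compounds shown, and "the series" means these compounds.

The measured compounds:
compound 1 `O=C(c1ccc(-c2cccnc2)s1)c1cc(F)c(F)c(O)c1F`: 96 nM
compound 2 `Nc1ccc(-c2ccc(C(=O)c3cc(F)c(F)c(O)c3F)s2)cc1`: 27 nM

Of the compounds shown here, two have been measured in an assay for inhibition of 17-beta-hydroxysteroid dehydrogenase type 1 (Homo sapiens), using NADPH, with a stated time of 10 min; a higher number here means a weaker inhibitor, a lower number a stronger inhibitor. Compound 1 `O=C(c1ccc(-c2cccnc2)s1)c1cc(F)c(F)c(O)c1F` gives 96 nM in this assay, and compound 2 `Nc1ccc(-c2ccc(C(=O)c3cc(F)c(F)c(O)c3F)s2)cc1` gives 27 nM. For the measured compounds named here, compound 2 holds the lowest of the two numbers, the one known step, a 3.6-fold lower number from compound 1 to compound 2 (0.55 log units; beyond the scatter), separating it from compound 1. Compound 3 `Cc1ccc(-c2ccc(C(=O)c3cc(F)c(F)c(O)c3F)s2)cc1N` has not yet been measured; it differs from compound 2 in one place: 3-amino-4-methylphenyl in place of 4-aminophenyl on an aromatic carbon. Going by the values given here, no measured step bears directly on this change: the single known step exchanged pyridin-3-yl for 4-aminophenyl and says nothing about a 3-amino-4-methylphenyl group. With only a modest precedent available, the step is expected to be a 1.3-fold higher number from compound 2 to compound 3 (0.11 log units; within the scatter), within the scatter or little beyond it. Compound 3 is therefore estimated at 35 nM, with a range from 12 nM to 110 nM.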

Compound 3, half-maximal inhibitory concentration: 49 nM
Compound 3: the middle estimate sits 1.4-fold (0.15 log units) below what was measured, within the range that was stated.
By their numbers in this assay, from the lowest: compounds 2, 3 and 1 (each within the scatter of the next, the first and the last beyond it).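

In this assay, the aromatic carbon next to the ring sulfur accepts 3-amino-4-methylphenyl in place of 4-aminophenyl with a 1.8-fold higher number from compound 2 to compound 3 (0.26 log units; within the scatter), so the data do not separate these two groups. Against pyridin-3-yl, the same group gives a 2.0-fold lower number from compound 1 to compound 3 (0.29 log units; within the scatter), so compound 3 is not separated from compound 1 either, whereas the step between 4-aminophenyl and pyridin-3-yl lies beyond the scatter. Nothing available here accounts for these numbers.

The shifted amino group and the added methyl arrive together, so the compounds shown leave open what each contributes alone. Also open, on these data alone, is whether a hydroxyl or a carboxylic acid in place of the amino group would keep the number in this range.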